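Swapping amino for fluoro on the shared core

The source may report more compounds than this note shows. Statements on the series, on what has been measured and on what is new or still open speak of the compounds shown alone.

Compound 3 `CC(=O)OC(C)n1cnc2c(S)nc(N)nc21` gives 89000 nM in a functional assay on HeLa cells (Homo sapiens) for inhibition; a lower number here means a stronger inhibitor, a higher number a weaker inhibitor. Among the two plain numbers shown it is the higher, with compound 2 `CC(=O)OC(C)n1cnc2c(Cl)nc(F)nc21` giving 50000 nM in this assay, a gap within the scatter. Compound 1 `CC(=O)OC(C)n1cnc2c(Cl)nc(N)nc21` gives only a limit of the assay, > 500000 nM. Compound 4 `CC(=O)OC(C)n1cnc2c(S)nc(F)nc21` differs from compound 3 by one change: fluoro in place of amino on an aromatic carbon. The same exchange has been measured once, where the step of an at least 10-fold lower number from compound 1 to compound 2 (1.00 log units; beyond the scatter) was seen, against the limit (the limit of > 500000 nM in this assay, at which 1 of the 3 values shown sits). Because that step an at least 10-fold lower number from compound 1 to compound 2 (1.00 log units; beyond the scatter) reached beyond the scatter, a clearly lower number is expected for compound 4 in this assay. Compound 4 is therefore estimated at 9000 nM, with a range from 2000 nM to 40000 nM, which means an expected step of a 9.9-fold lower number from compound 3 to compound 4 (1.00 log units; beyond the scatter).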

Compound 4, half-maximal inhibitory concentration: > 500000 nM
Compound 4: no number, only a limit; the forecaster's own chance of this, stated with the estimate: 0%; middle value at least 55-fold (1.74 log units) from the limit.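

Fluoro in place of amino now gives an at least 5.6-fold higher number from compound 3 to compound 4 (0.74 log units; beyond the scatter) in this assay, so the outcome of this change between two ring nitrogen atoms depends on whether chloro or sulfanyl is also on the core: the same change on two cores in this assay, an at least 10-fold lower number (1.00 log units; beyond the scatter) from compound 1 to compound 2 and an at least 5.6-fold higher number (0.74 log units; beyond the scatter) from compound 3 to compound 4, at least 56-fold (1.74 log units) apart, beyond the scatter of two such steps

Sulfanyl in place of chloro likewise gives an at least 10-fold higher number from compound 2 to compound 4 (1.00 log units; beyond the scatter) when fluoro is present, the opposite direction to its step with amino present: the same change on two cores in this assay, an at least 5.6-fold lower number (0.74 log units; beyond the scatter) from compound 1 to compound 3 and an at least 10-fold higher number (1.00 log units; beyond the scatter) from compound 2 to compound 4, at least 56-fold (1.74 log units) apart, beyond the scatter of two such steps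

From the compounds shown here alone, compound 4 gives only a limit of the assay, so the full size of both steps remains unknown.

Going by these compounds, whether this dependence extends to other groups at this position, such as methoxy or a methylamino group, remains open.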